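The source may hold more compounds than are shown below. What is called first, only, known or untested is meant among the compounds shown, and "the series" means these compounds.

Measured compounds:
compound 1 `CC1(C)CC(NC(=S)Nc2cccc(Cl)c2)c2cc(NS(C)(=O)=O)ccc2O1` gives 9800 nM in a functional assay on thoracic aorta (Rattus norvegicus) for inhibition; on this read-out higher numbers stand for an effect only at larger amounts of compound and lower numbers for an effect already at smaller amounts
compound 2 `CCS(=O)(=O)Nc1ccc2c(c1)C(NC(=S)Nc1ccc(C#N)cc1)CC(C)(C)O2` gives 12000 nM in this assay

Compound 2 carries the highest of the two numbers, but its gap to compound 1 lies within the scatter, so no order between them is claimed. Compound 3 `CCS(=O)(=O)Nc1ccc2c(c1)C(NC(=S)Nc1cccc(Cl)c1)CC(C)(C)O2` is not yet measured. It differs from compound 2 by 3-chlorophenyl in place of 4-cyanophenyl on an amide-type nitrogen, the same group that compound 1 carries. Expected: no step beyond the scatter, a change from compound 2 to compound 3 of about a 1.3-fold lower number from compound 2 to compound 3 (0.10 log units; within the scatter). For compound 3 the estimate in this assay is 9500 nM, with a range of 4000 nM to 22000 nM.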

Compound 3, half-maximal effective concentration: 9800 nM
Estimate against measurement, compound 3: 1.0-fold (0.01 log units) below; the measured number falls inside the stated range.
By their numbers in this assay, from the lowest: compounds 1, 3 and 2 (each within the scatter of the next).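

In this assay, 3-chlorophenyl in place of 4-cyanophenyl on the amide-type nitrogen gives a 1.2-fold lower number from compound 2 to compound 3 (0.09 log units; within the scatter), so this exchange, now readable on its own, shows no step beyond the scatter. Methyl in place of hydrogen on the saturated chain carbon bound to the sulfonyl sulfur gives no change at the digits printed from compound 1 to compound 3 (within the scatter), so that added methyl also leaves the number within the scatter. Open, going by these compounds, is whether an amine or a carboxylic acid on the phenyl group, or a longer chain on the sulfonyl sulfur, would give a step beyond the scatter. No measurement at hand gives a reason for either result.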